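The compounds below may be only part of what the source reports. "The series", "measured", "known", "first", "only" and "open" are said of these compounds alone.

Compound 2, with the structure `COc1cc(/C=C/C(=O)c2cccc(-n3cc(-c4cccc(Cl)c4)nn3)c2)ccc1O`, is one of three close analogues measured in a functional assay on RAW264.7 cells (Mus musculus) for inhibition, with a stated time of 4 days; a higher number here means a weaker inhibitor, a lower number a stronger inhibitor. Its partner compound 1, `COc1cc(/C=C/C(=O)c2cccc(-n3cc(-c4ccc(F)cc4)nn3)c2)ccc1O`, gives 6450 nM in this assay, and compound 3, `COc1cc(/C=C/C(=O)c2cccc(-n3cc(-c4cc(F)cc(F)c4)nn3)c2)ccc1O`, gives 22800 nM; compound 2 itself gives 14300 nM. Among these three numbers compound 2 stands second highest, within the scatter of compound 3 and beyond the scatter of compound 1.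

The measured steps all change the group on the aromatic carbon: a 2.2-fold higher number from compound 1 to compound 2 (0.35 log units; beyond the scatter), a 3.5-fold higher number from compound 1 to compound 3 (0.55 log units; beyond the scatter), and a 1.6-fold higher number from compound 2 to compound 3 (0.20 log units; within the scatter). The step to compound 4, `COc1ccc(/C=C/C(=O)c2cccc(-n3cc(-c4cccc(Cl)c4)nn3)c2)cc1O`, touches a different part of the molecule: 3-hydroxy-4-methoxyphenyl in place of 4-hydroxy-3-methoxyphenyl on a double-bonded chain carbon bound to a double-bonded chain carbon. Going by the values given here, no measured step in this set alters the hydroxy-methoxyphenyl group, so none of the three steps bears directly on this change, and nothing among them points in either direction. The shared core and the 3-chlorophenyl group are unchanged from compound 2.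

On that basis the expectation for compound 4 in this assay is a step of a 1.0-fold lower number from compound 2 to compound 4 (0.01 log units; within the scatter), that is, no change beyond the scatter. Compound 4 is therefore estimated at 14000 nM, with a range from 6000 nM to 33000 nM.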

Compound 4, half-maximal inhibitory concentration: 6610 nM
Compound 4: the middle estimate sits 2.1-fold (0.33 log units) above what was measured, and the stated range covers the measured number.
By their numbers in this assay, from the lowest: compounds 1 and 4 (each within the scatter of the next); then compounds 2 and 3 (each within the scatter of the next).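

In this assay, the group on the double-bonded chain carbon bound to a double-bonded chain carbon proves able to shift the number: 3-hydroxy-4-methoxyphenyl in place of 4-hydroxy-3-methoxyphenyl gives a 2.2-fold lower number from compound 2 to compound 4 (0.34 log units; beyond the scatter), a modest step. Going by these compounds alone, the earlier compounds varied only the group on the aromatic carbon, so this is the first sign that the other end of the molecule matters as well, and here the entering and leaving groups have the same heavy atoms and the same counts of hydrogen-bond donors and acceptors, differing only in how those atoms are joined. Nothing measured alongside this step accounts for it, and the data give no reason for the shift.

This swap is shown only with the 3-chlorophenyl group, so it remains open whether the same step would appear with the 4-fluorophenyl or 3,5-difluorophenyl groups. It is also open how far the hydroxy group itself contributes, as the compounds shown offer no analogue in which a second methoxy group, an amine or a carboxylic acid stands in its place.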